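This account rests on a few compounds, and the source may have more. Where it says the series, first, only, none or still open, it means among the compounds named here.

Three amides sharing one core, and differing only in the ring on the carbonyl carbon, have been tested in a functional assay on HCT-116 cells (Homo sapiens) for antiproliferative activity, read by resazurin assay, with a stated time of 5 days; a higher number here means a weaker inhibitor, a lower number a stronger inhibitor. Compound 1 `O=C(NCc1ccc2cc(C(=O)NO)sc2c1F)c1ccco1`, with furan-2-yl, gives 90 nM. Compound 2 `O=C(NCc1ccc2cc(C(=O)NO)sc2c1F)c1ccc[nH]1`, with 1H-pyrrol-2-yl, gives 300 nM. Compound 3 `O=C(NCc1ccc2cc(C(=O)NO)sc2c1F)c1ccccc1`, with phenyl, gives 980 nM, the highest number of the set, which makes it the weakest inhibitor of the group. Swapping the ring has had clear effects: an 11-fold higher number from compound 1 to compound 3 (1.04 log units; beyond the scatter) is large, while a 3.3-fold higher number from compound 1 to compound 2 (0.52 log units; beyond the scatter) and a 3.3-fold higher number from compound 2 to compound 3 (0.51 log units; beyond the scatter) are modest, and all lie beyond the usual scatter.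

Compound 4 `COc1ccc(C(=O)NCc2ccc3cc(C(=O)NO)sc3c2F)cc1` keeps the phenyl ring of compound 3 but has methoxy in place of hydrogen on an aromatic carbon, para to a large group, so phenyl becomes 4-methoxyphenyl (methoxy in place of hydrogen on an aromatic carbon). For the measured compounds named here, no measured step adds a group to a ring, since each replaces the whole ring, so the data give no direction for this change. Taking the modest 3.3-fold higher number from compound 2 to compound 3 (0.51 log units; beyond the scatter) as a rough ceiling for a smaller edit, no shift beyond the scatter is expected. The expected result is a 1.2-fold lower number from compound 3 to compound 4 (0.09 log units; within the scatter), an estimate without a firm direction. In this assay, the estimate for compound 4 is 800 nM, expected to fall between 320 nM and 2000 nM.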

Compound 4, half-maximal inhibitory concentration: 50 nM
Estimate against measurement, compound 4: 16-fold (1.20 log units) above; the whole stated range lies above it.
By their numbers in this assay, from the lowest: compounds 4 and 1 (each within the scatter of the next); then compound 2; then compound 3.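

Adding methoxy to the phenyl ring changes the picture in this assay: the result is a 20-fold lower number from compound 3 to compound 4 (1.29 log units; beyond the scatter), so a small group para to a large group can matter as much as replacing the whole ring. The earlier compounds shown here, each with a different ring, made phenyl look like the poor choice, but the ring's identity alone does not settle the outcome, as 4-methoxyphenyl gives a 6.0-fold lower number from compound 2 to compound 4 (0.78 log units; beyond the scatter) and a 1.8-fold lower number from compound 1 to compound 4 (0.26 log units; within the scatter), which leaves compound 4 level with compound 1 rather than ahead of it. No measurement shown here explains why this one added group has so large an effect.

The compounds shown leave open whether this gain belongs to methoxy itself or would also come with a hydroxyl, a chlorine atom, an amine or a longer chain such as ethoxy on the same aromatic carbon. They also leave open whether methoxy would help on another carbon of the phenyl ring, or whether a similar addition to the furan-2-yl ring of compound 1 would bring any further change.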